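A few compounds are considered here, and "the series" means these few. Any claim that something is new, unique, unknown or untested is made for them only; others in the source may bear on it.

Working notes on the series. Compound 3 `O=C(Nc1nc2ccc(Cl)cc2s1)c1cn(-c2ccccc2)nc1-c1ccc(F)cc1` is the reference point. In a functional assay on A549 cells (Homo sapiens) for cytotoxicity, read by MTT assay, with a stated time of 72 h (a higher number here means a weaker inhibitor, a lower number a stronger inhibitor), compound 3 gives 3870 nM. Compound 1 `O=C(Nc1nc2ccc(Cl)cc2s1)c1cn(-c2ccccc2)nc1-c1ccccc1` gives 7670 nM in this assay, and compound 2 `O=C(Nc1nc2ccccc2s1)c1cn(-c2ccccc2)nc1-c1ccc(F)cc1` gives 9010 nM. Compound 3 thus carries the lowest of the three numbers, but only its gap to compound 2 lies beyond the scatter, as a 2.3-fold lower number from compound 2 to compound 3 (0.37 log units; beyond the scatter) shows; the step of a 2.0-fold lower number from compound 1 to compound 3 (0.30 log units; within the scatter) is within the scatter.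

Compound 4 `Cc1ccc2nc(NC(=O)c3cn(-c4ccccc4)nc3-c3ccc(F)cc3)sc2c1` has not been measured. It differs from compound 3 in one place: methyl in place of chloro on an aromatic carbon. Of the measured steps only a 2.3-fold lower number from compound 2 to compound 3 (0.37 log units; beyond the scatter) concerns the same position, where chloro in place of hydrogen lowered the number modestly. Nothing measured shows methyl at that position, so the size of the step for methyl in place of chloro is not anchored. The most that can be read from the three numbers is that a substituent at this position has moved the result only modestly, and an exchange of one small substituent for another is expected to stay within the scatter, with at most a slight drift back toward compound 2. Compound 4 is expected to give about 5500 nM in this assay, between 2500 nM and 12000 nM. The expected step of a 1.4-fold higher number from compound 3 to compound 4 (0.15 log units; within the scatter) is therefore none beyond the scatter.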

Compound 4, half-maximal inhibitory concentration: 24600 nM
Estimate against measurement, compound 4: 4.5-fold (0.65 log units) below, and the stated range ends below it.
By their numbers in this assay, from the lowest: compounds 3, 1 and 2 (each within the scatter of the next, the first and the last beyond it); then compound 4.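

In this assay, the 6-chloro-1,3-benzothiazol-2-yl to 6-methyl-1,3-benzothiazol-2-yl exchange is not a neutral swap of one small substituent for another: a 6.4-fold higher number from compound 3 to compound 4 (0.80 log units; beyond the scatter) is the largest step in the series, although each group counts a single heavy atom and neither adds a hydrogen-bond donor or acceptor. Set against hydrogen at the same aromatic carbon, the two groups move the number in opposite directions, with a 2.3-fold lower number from compound 2 to compound 3 (0.37 log units; beyond the scatter) for chloro and a 2.7-fold higher number from compound 2 to compound 4 (0.44 log units; beyond the scatter) for methyl, so this position responds to the identity of the group and not merely to the presence of a substituent. Nothing available on the compounds accounts for this reversal.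

With only hydrogen, chloro and methyl shown at this position, the compounds leave open where groups such as fluoro, methoxy, trifluoromethyl or an amine would fall relative to these three. They also leave open whether methyl in place of chloro gives a step of similar size on the core of compound 1, which lacks the fluoro of compound 3.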